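The source may report more compounds than this note shows. Statements on the series, on what has been measured and on what is new or still open speak of the compounds shown alone.

Three close relatives of a single scaffold have been tested in an ADME assay on MT4 cells (Homo sapiens) for cytotoxicity, read by MTT assay, with a stated time of 5 days (on this read-out lower numbers stand for higher toxicity in this test and higher numbers for lower toxicity in this test), and all three ran off the top of the measurable range. Compound 1 `Cc1cc(/C=C/C#N)cc(C)c1Oc1nc(Nc2ccc(N3CCCC(NS(N)(=O)=O)C3)cc2)nc2ccsc12` gives > 217000 nM in this assay, which is a limit rather than a number. Compound 2 `Cc1cc(/C=C/C#N)cc(C)c1Oc1nc(Nc2ccc(N3CCN(S(N)(=O)=O)CC3)cc2)nc2sccc12` gives > 222000 nM in this assay, again a limit. Compound 3 `Cc1cc(/C=C/C#N)cc(C)c1Oc1nc(Nc2ccc(CN3CCN(S(N)(=O)=O)CC3)cc2)nc2sccc12` gives > 217000 nM in this assay, also a limit. Among the compounds with values here, because every value is a limit, the one single-change step that can be written down, a step that the two limits leave unreadable from compound 2 to compound 3, cannot be read, and the only evidence is that of the limit of > 217000 nM in this assay, at which 2 of the 3 values shown sit, and (the limit of > 222000 nM in this assay, at which 1 of the 3 values shown sits).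

The step to the new compound starts from compound 1. Compound 4 `Cc1cc(/C=C/C#N)cc(C)c1Oc1nc(Nc2ccc(N3CCCC(NS(C)(=O)=O)C3)cc2)nc2ccsc12` carries a single change: methyl in place of amino on a sulfonyl sulfur, turning the sulfamoylamino group into a methanesulfonamido group. No measured step speaks to this change, and no measured compound of this family has yet shown a readable toxicity. The expectation is therefore no movement beyond the scatter, with the reading most likely to end at the limit once more. Compound 4 is expected to come out near 217000 nM, within 100000 nM to 400000 nM. The expected change is a number no higher from compound 1 to compound 4 (the limit leaves the size open).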

Compound 4, half-maximal cytotoxic concentration: > 217000 nM
Compound 4 gave a limit, no number (the forecaster's own chance of this, stated with the estimate: 75%); the middle value sits exactly at the limit.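

In this assay compound 4 gives > 217000 nM, which is a limit. Compound 1 also stands at a limit, and the step between compound 1 and compound 4 cannot be read. The compounds shown leave open whether swapping sulfamoylamino for methanesulfonamido changes toxicity to these cells, and at what concentration any of these compounds becomes toxic.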